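Moving the Trifluoromethyl Group on the Phenyl Ring

The source may report more compounds than this note shows. Statements on the series, on what has been measured and on what is new or still open speak of the compounds shown alone.

Compound 1, `COc1cc(C2=NN(C(C)=O)C(c3ccccc3C(F)(F)F)O2)cc(OC)c1OC`, was tested in a functional assay on BGC-823 cells (Homo sapiens) for antiproliferative activity, read by MTT assay, tested at 1 uM (on this read-out higher numbers stand for a stronger effect at the one concentration tested and lower numbers for a weaker effect), where compound 1 gives 31.8%. Among the measured compounds shown here, this is the highest of the three numbers measured so far. Compound 2, `COc1cc(C(=O)N/N=C/c2cccc(C(F)(F)F)c2)cc(OC)c1OC`, gives 17.7% in this assay, a number that lies below compound 1 by more than the usual scatter. Compound 3, `COc1cc(C(=O)N/N=C/c2c(Cl)cccc2Cl)cc(OC)c1OC`, gives 0.9% in this assay and stands furthest from compound 1, again beyond the scatter. Both compound 2 and compound 3 differ from compound 1 in more than one place, so no single step can be read from them.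

Compound 4, `COc1cc(C2=NN(C(C)=O)C(c3ccc(C(F)(F)F)cc3)O2)cc(OC)c1OC`, has not yet been measured. It differs from compound 1 in one place: 4-(trifluoromethyl)phenyl in place of 2-(trifluoromethyl)phenyl on a saturated ring carbon. The two structures hold the same atoms, joined differently. No measured pair differs in just this way, so the size of such a step is not shown by the data. A change of this kind is expected to move the number only modestly, in either direction, and quite possibly by no more than the scatter. Compound 4 is therefore expected to give about 30% in this assay, with a likely range from 10% to 55%. The step of a number 1.8 percentage points lower from compound 1 to compound 4 (within the scatter) is the expected change this estimate implies.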

Compound 4, a percentage reported as inhibition, at one concentration (the size of the read-out at that concentration, not a potency): 4.2%
Estimate against measurement, compound 4: 25.8 percentage points above; the measured number lies below the stated range.
By their numbers in this assay, from the lowest: compounds 3 and 4 (each within the scatter of the next); then compound 2; then compound 1.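

Among the compounds shown here, with the same atoms on both sides, the only thing that changes here is where the trifluoromethyl group sits on the phenyl ring, and in this assay that change alone gives a number 27.6 percentage points lower from compound 1 to compound 4 (beyond the scatter). The earlier compounds shown here could not show this, as they differ from compound 1 in more than one place, whereas this pair shows that the saturated ring carbon of the shared core is sensitive to the arrangement of its aryl group, not just to which atoms it carries. Nothing measured here explains why the 2-(trifluoromethyl)phenyl compound gives the higher number, so this remains an observation from a single pair.

Going by these compounds, it remains open whether other groups at this ring carbon, such as 2-methoxyphenyl, 2-aminophenyl or a phenyl ring bearing a carboxylic acid, would keep or lose the effect seen with compound 1. Also unresolved is whether the gap between compound 1 and compound 4 would hold at other concentrations, since a reading at one concentration is not a potency.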